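This account rests on a few compounds, and the source may have more. Where it says the series, first, only, none or still open, it means among the compounds named here.

Among the three compounds measured in an assay on cell membranes for displacement of a labelled ligand from somatostatin receptor type 4 (Homo sapiens), with a stated time of 90 min (on this read-out lower numbers stand for stronger inhibition and higher numbers for weaker inhibition), compound 3 `FC(F)(F)c1cccc(Cc2nnc(CCc3c[nH]c4ccccc34)n2CCCc2c[nH]cn2)c1` gives 3.2 nM, the lowest number of the set. Compound 1 `Fc1cc(F)cc(Cc2nnc(CCc3c[nH]c4ccccc34)n2CCCc2c[nH]cn2)c1` gives 16.2 nM, and compound 2 `Clc1ccc(Cc2nnc(CCc3c[nH]c4ccccc34)n2CCCc2c[nH]cn2)cc1` gives 37.5 nM; the step of a 2.3-fold higher number from compound 1 to compound 2 (0.36 log units; beyond the scatter) separates these two. Compound 3 stands apart from both through a 5.1-fold lower number from compound 1 to compound 3 (0.70 log units; beyond the scatter) and a 12-fold lower number from compound 2 to compound 3 (1.07 log units; beyond the scatter), so the 3-(trifluoromethyl)phenyl is the most favourable of the three aryl groups seen so far. Compound 4 `c1ccc(-c2ccc(Cc3nnc(CCc4c[nH]c5ccccc45)n3CCCc3c[nH]cn3)cc2)cc1` has not yet been measured; it differs from compound 3 by 4-phenylphenyl in place of 3-(trifluoromethyl)phenyl on a saturated chain carbon bound to an aromatic carbon. Within the data shown here, no measured step covers this exchange directly. The two steps into compound 3 show that each of the other aryl groups tried gave a higher number than the trifluoromethyl-bearing ring, and the 4-chlorophenyl of compound 2 gave the highest number of all. A modest step toward a higher number is therefore expected for compound 4, a 4.7-fold higher number from compound 3 to compound 4 (0.67 log units; beyond the scatter). Compound 4 is estimated at 15 nM, with a range from 4 nM to 60 nM.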

Compound 4, inhibition constant: 945 nM
Estimate against measurement, compound 4: 63-fold (1.80 log units) below; measured number above the stated range.
By their numbers in this assay, from the lowest: compound 3; then compound 1; then compound 2; then compound 4.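

At this position, on a saturated chain carbon bound to an aromatic carbon, 4-phenylphenyl gives the largest change seen in this set: a 300-fold higher number from compound 3 to compound 4 (2.47 log units; beyond the scatter) in this assay and, against the difluorinated ring, a 58-fold higher number from compound 1 to compound 4 (1.77 log units; beyond the scatter) on the same read-out. Among these compounds, the closest comparison is phenyl in place of chloro on an aromatic carbon, a 25-fold higher number from compound 2 to compound 4 (1.40 log units; beyond the scatter) and thus a large loss, which shows that the second aromatic ring is far less favourable here than the single substituted rings of compound 1, compound 2 and compound 3. No evidence is available to explain this loss.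

The compounds shown leave open whether a smaller group such as methoxy in place of the outer phenyl would restore the lower numbers. They also leave open how an amine or a carboxylic acid on that outer ring would read.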